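A few compounds are considered here, and "the series" means these few. Any claim that something is new, unique, unknown or untested is made for them only; others in the source may bear on it.

In a functional assay on NCI-H1993 cells (Homo sapiens) for inhibition, read by CCK-8 assay, with a stated time of 72 h (on this read-out higher numbers stand for weaker inhibition and lower numbers for stronger inhibition), compound 1 (`CC(c1cc2cccnc2cc1F)n1cnc2ncc(-c3cnn(CCO)c3)nc21`) gives 175 nM and compound 2 (`CC(c1cc2cccnc2cc1F)n1cnc2ncc(-c3ccncc3)nc21`) gives 171 nM, so compound 2 stands level with compound 1 within the scatter. Compound 3 (`CC(c1cc2cccnc2cc1F)n1cnc2ncc(-c3ccccc3)nc21`) carries phenyl in place of pyridin-4-yl on an aromatic carbon of the shared core: phenyl in place of pyridin-4-yl on an aromatic carbon. Among the measured compounds shown here, only one measured step bears on this position: a 1.0-fold lower number from compound 1 to compound 2 (0.01 log units; within the scatter), with pyridin-4-yl replacing 1-(2-hydroxyethyl)-1H-pyrazol-4-yl, and it lies within the scatter. For the measured compounds named here, no measured compound has an aromatic ring of carbon only at this position, so this guidance is limited. On the basis of that step, no change beyond the scatter is expected in this assay, with a slight lean toward weaker inhibition: the expected step is a 1.5-fold higher number from compound 2 to compound 3 (0.16 log units; within the scatter). The estimated value for compound 3 is 250 nM, within an expected range of 90 nM to 700 nM.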

Compound 3, half-maximal inhibitory concentration: 570 nM
Compound 3: the middle estimate sits 2.3-fold (0.36 log units) below what was measured, within the range that was stated.
By their numbers in this assay, from the lowest: compounds 2 and 1 (each within the scatter of the next); then compound 3.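

In this assay, the phenyl ring of compound 3 separates from both nitrogen-bearing rings, with a 3.3-fold higher number from compound 2 to compound 3 (0.52 log units; beyond the scatter) and a 3.3-fold higher number from compound 1 to compound 3 (0.51 log units; beyond the scatter), each modest but beyond the scatter. The level pair of earlier compounds gave no sign of this: the position does respond to its substituent, and between pyridin-4-yl and phenyl the change is only the ring nitrogen giving way to carbon. Nothing at hand explains the weaker inhibition on going to phenyl.

Still open, on these data alone, is whether the ring nitrogen must sit where pyridin-4-yl places it, as pyridin-3-yl or pyrimidin-5-yl would test. Also open, as far as these compounds go, is whether a phenyl ring carrying an amine or a carboxylic acid would return to the level of compound 2.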